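The source may hold more compounds than are shown below. What is called first, only, known or untested is meant among the compounds shown, and "the series" means these compounds.

Going by the values given here, compound 2 `FC(F)(F)c1cc(COCC2(c3ccccc3)CCC(NC3CC3)C2)cc(C(F)(F)F)c1` gives 16 nM in an assay on isolated protein for antagonist activity at Substance-P receptor (Homo sapiens) (on this read-out lower numbers stand for stronger inhibition and higher numbers for weaker inhibition), the higher of the two numbers measured so far; compound 1 `FC(F)(F)c1cc(COCC2(c3ccccc3)CCC(N3CCCCC3)C2)cc(C(F)(F)F)c1` gives 4.7 nM in this assay. Among the compounds with values here, the single measured step, a 3.4-fold higher number from compound 1 to compound 2 (0.53 log units; beyond the scatter), replaces a tertiary amine that is part of a ring with a secondary one. Compound 3 `CC(C)N(C(C)C)C1CCC(COCc2cc(C(F)(F)F)cc(C(F)(F)F)c2)(c2ccccc2)C1` differs from compound 2 by diisopropylamino in place of cyclopropylamino on a saturated ring carbon, so it returns to a tertiary amine, here without a ring. That step bears on it only loosely, and the expected change in this assay is therefore modest and toward a lower number, a 1.6-fold lower number from compound 2 to compound 3 (0.20 log units; within the scatter). Compound 3 is estimated at 10 nM in this assay, within 3 nM to 35 nM.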

Compound 3, half-maximal inhibitory concentration: 470 nM
The estimate for compound 3 lay 47-fold (1.67 log units) below the measured number; measured number outside the range, above it.
By their numbers in this assay, from the lowest: compound 1; then compound 2; then compound 3.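

At this position a tertiary amine alone does not keep the number low in this assay: diisopropylamino gives a 29-fold higher number from compound 2 to compound 3 (1.47 log units; beyond the scatter) and a 100-fold higher number from compound 1 to compound 3 (2.00 log units; beyond the scatter). Among these three amines, the tertiary piperidin-1-yl and diisopropylamino groups mark the two ends of the range, with secondary cyclopropylamino between them, so amine class does not order the series. No measured evidence accounts for the loss seen with diisopropylamino.

The compounds shown leave open whether the loss follows the absence of a ring on the nitrogen or the bulk of the branched chains. A dimethylamino group on the same saturated ring carbon would help separate the two.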